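Replacing dimethylamino with methyl in compound 3

This account rests on a few compounds, and the source may have more. Where it says the series, first, only, none or still open, it means among the compounds named here.

Measured in a functional assay on NB1 cells (Homo sapiens) for antiproliferative activity, with a stated time of 72 h; a lower number here means a stronger inhibitor, a higher number a weaker inhibitor:
- compound 1 `Cc1cc(C)cc(C(=O)N(CCC(=O)NCc2ccccc2)Cc2ccc(C(=O)NO)cc2)c1`: 3870 nM
- compound 2 `O=C(CCN(Cc1ccc(C(=O)NO)cc1)C(=O)c1ccccc1)NCc1ccccc1`: 6660 nM
- compound 3 `CN(C)c1ccc(C(=O)N(CCC(=O)NCc2ccccc2)Cc2ccc(C(=O)NO)cc2)cc1`: 1720 nM

Compound 3 has the lowest number of the three, and its gaps to the other two lie beyond the scatter. Compound 4 `Cc1ccc(C(=O)N(CCC(=O)NCc2ccccc2)Cc2ccc(C(=O)NO)cc2)cc1` carries methyl in place of dimethylamino on an aromatic carbon. Two measured steps show what dimethylamino has accompanied: a 3.9-fold lower number from compound 2 to compound 3 (0.59 log units; beyond the scatter) and a 2.3-fold lower number from compound 1 to compound 3 (0.35 log units; beyond the scatter), both modest. The step that changes only methyl groups, a 1.7-fold higher number from compound 1 to compound 2 (0.24 log units; within the scatter), lies within the scatter. In this assay, a modest rise is therefore expected, back towards compound 1 and compound 2. The expected change is a 2.1-fold higher number from compound 3 to compound 4 (0.32 log units; beyond the scatter). The estimated value for compound 4 is 3600 nM, with an expected range of 1800 nM to 7000 nM.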

Compound 4, half-maximal inhibitory concentration: 1610 nM
Beside the measured number, compound 4's estimate is 2.2-fold (0.35 log units) above it; measured number below the stated range.
By their numbers in this assay, from the lowest: compounds 4 and 3 (each within the scatter of the next); then compounds 1 and 2 (each within the scatter of the next).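

In this assay, methyl does as well at this position on the aromatic ring as dimethylamino, with a 1.1-fold lower number from compound 3 to compound 4 (0.03 log units; within the scatter) and so the earlier gain is not tied to dimethylamino. A single methyl there accompanies a 4.1-fold lower number from compound 2 to compound 4 (0.62 log units; beyond the scatter) while a 2.4-fold lower number from compound 1 to compound 4 (0.38 log units; beyond the scatter) sets 4-methylphenyl apart from 3,5-dimethylphenyl on the carbonyl carbon. No measurement is available to account for these results. The compounds shown leave open whether chlorine, methoxy or a carboxylic acid at this position would match methyl and dimethylamino.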